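A Hydroxy Swap on a Glycoside Ester Side Chain

This account rests on a few compounds, and the source may have more. Where it says the series, first, only, none or still open, it means among the compounds named here.

Compound 1 `C/C=C1/[C@H](O[C@@H]2O[C@H](CO)[C@@H](O)[C@H](O)[C@H]2O)OC=C(C(=O)OC)[C@H]1CC(=O)OCC` and compound 2 `C/C=C1/[C@H](O[C@@H]2O[C@H](CO)[C@@H](O)[C@H](O)[C@H]2O)OC=C(C(=O)OC)[C@H]1CC(=O)OCCc1ccc(F)cc1` share one core and differ only by a 4-fluorophenyl in place of hydrogen on a saturated chain carbon. In a functional assay on SK-BR-3 cells (Homo sapiens) for antiproliferative activity, read by MTT assay, with a stated time of 72 h (on this read-out lower numbers stand for stronger inhibition and higher numbers for weaker inhibition), compound 1 gives the limit > 15000 nM. In this assay compound 2 gives the limit > 20000 nM. The step that the two limits leave unreadable from compound 1 to compound 2 cannot be sized because the limit of > 15000 nM in this assay, at which 1 of the 2 values shown sits, and the limit of > 20000 nM in this assay, at which 1 of the 2 values shown sits, are both limits. Compound 3 `C/C=C1/[C@H](O[C@@H]2O[C@H](CO)[C@@H](O)[C@H](O)[C@H]2O)OC=C(C(=O)OC)[C@H]1CC(=O)OCCc1ccc(O)cc1` carries hydroxy in place of fluoro on an aromatic carbon. Among the measured compounds shown here, no measured step bears on this change, so no step beyond the scatter is expected, and the estimated step is a step that the limit leaves unreadable from compound 2 to compound 3. Compound 3 is expected to give 25000 nM, within 8000 nM to 80000 nM.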

Compound 3, half-maximal inhibitory concentration: > 20000 nM
Compound 3 ended at the assay's limit (the forecaster's own chance of this, stated with the estimate: 80%); the middle value is on the limit's open side.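

In this assay, among the compounds shown here, compound 3 gives > 20000 nM, which is a limit, so no step linking it to compound 1 or compound 2 can be read. The compounds shown leave open how compound 2 and compound 3 truly compare, and whether any of these ester side chains gives a measurable value in this assay.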